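Swapping the aryl amine on a shared quinazoline-free core

The source may hold more compounds than are shown below. What is called first, only, known or untested is meant among the compounds shown, and "the series" means these compounds.

Compound 1 `FC(F)(F)c1ccc(CSc2nc(N3CCCCC3)c3ccccc3n2)cc1` in a functional assay on MCF7 cells (Homo sapiens) for cytotoxicity, read by MTT assay, with a stated time of 72 h (on this read-out lower numbers stand for stronger inhibition and higher numbers for weaker inhibition), gives > 50000 nM, which is a limit of the assay rather than a number.
Compound 2 `FC(F)(F)c1ccc(CSc2nc(Nc3cccc(C(F)(F)F)c3)c3ccccc3n2)cc1` in this assay gives 15300 nM.
Compound 3 `FC(F)(F)c1ccc(CSc2nc(Nc3ccc(C(F)(F)F)cc3)c3ccccc3n2)cc1` in this assay gives 5100 nM.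

Compound 3 stands with the lowest of the two numbers shown; the nearest is compound 2, and the step of a 3.0-fold lower number from compound 2 to compound 3 (0.48 log units; beyond the scatter) lies beyond the scatter. Replacing the saturated amine of compound 1 by an aryl amine gives an at least 3.2-fold lower number from compound 1 to compound 2 (0.51 log units; beyond the scatter) and an at least 9.8-fold lower number from compound 1 to compound 3 (0.99 log units; beyond the scatter), both from a limit (the limit of > 50000 nM in this assay, at which 1 of the 3 values shown sits), so only their least size is known.

Compound 4 `COc1ccc(Nc2nc(SCc3ccc(C(F)(F)F)cc3)nc3ccccc23)c(OC)c1` differs from compound 3 by 2,4-dimethoxyphenyl in place of 4-(trifluoromethyl)phenyl on a nitrogen on an aromatic ring. Going by the values given here, no measured step changes the substituents on that phenyl ring in this way; the only step on that ring, a 3.0-fold lower number from compound 2 to compound 3 (0.48 log units; beyond the scatter), shows that where a group sits on it matters modestly. The change is therefore expected to move this assay by a modest amount at most, with direction uncertain.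

The estimate for compound 4 is 9000 nM, within 2500 nM to 35000 nM, which is expected to mean a 1.8-fold higher number from compound 3 to compound 4 (0.25 log units; within the scatter).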

Compound 4, half-maximal inhibitory concentration: > 50000 nM
Compound 4 gave a limit, no number (the forecaster's own chance of this, stated with the estimate: 15%); at least 5.5-fold (0.74 log units) between middle value and limit.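

An aryl amine on the shared core is therefore not enough on its own for a measurable number in this assay: 2,4-dimethoxyphenyl in place of 4-(trifluoromethyl)phenyl gives an at least 9.8-fold higher number from compound 3 to compound 4 (0.99 log units; beyond the scatter), and in place of 3-(trifluoromethyl)phenyl it gives an at least 3.2-fold higher number from compound 2 to compound 4 (0.51 log units; beyond the scatter). What the phenyl ring carries thus matters, not just the presence of the ring. Only the least size of these steps is known, and the step from compound 1 to compound 4 cannot be read, since both ends are limits: the limit of > 50000 nM in this assay, at which 2 of the 4 values shown sit.

The compounds shown leave open whether both methoxy groups are tied to this loss or one alone would do. They also do not show how a plain phenyl, or a phenyl carrying a single methoxy group or a chlorine, would behave.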